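A few compounds are considered here, and "the series" means these few. Any claim that something is new, unique, unknown or untested is made for them only; others in the source may bear on it.

Compound 1, `COC(=O)/C=C/c1cccc(N(Cc2ccc(/C=C/c3ccccc3F)cc2)C(=O)C2CCCCC2)c1`, gives 64 nM in an assay on isolated protein with Bile acid receptor (Homo sapiens) as the target; a lower number here means that less compound is needed, a higher number that more compound is needed for the effect.
Compound 2, `COC(=O)/C=C/c1cccc(N(Cc2ccc(-c3cccc(Cl)c3)cc2)C(=O)C2CCCCC2)c1`, gives 94 nM in this assay.
Compound 3, `COC(=O)/C=C/c1cccc(N(Cc2ccc(/C=C/C(=O)O)cc2)C(=O)C2CCCCC2)c1`, is reported in this assay only as a limit, > 1000 nM.

Among the compounds with values here, compound 3 therefore stands at the edge of what the assay reports; it is the one compound at the limit of > 1000 nM in this assay, at which 1 of the 3 values shown sits. Compound 4, `COC(=O)/C=C/c1cccc(N(Cc2ccc(/C=C/c3cccc(Cl)c3)cc2)C(=O)C2CCCCC2)c1`, differs from it in one place: 3-chlorophenyl in place of carboxy on a double-bonded chain carbon bound to a double-bonded chain carbon. The relevant measured steps run the other way, into compound 3: an at least 15-fold higher number from compound 1 to compound 3 (1.19 log units; beyond the scatter) and an at least 10-fold higher number from compound 2 to compound 3 (1.02 log units; beyond the scatter). Both show that putting the carboxy group there raised the number strongly, so removing it in favour of a 3-chlorophenyl group is expected to lower the number strongly, roughly an at least 14-fold lower number from compound 3 to compound 4 (1.15 log units; beyond the scatter). Compound 4 is thus estimated at 70 nM, with a range from 30 nM to 200 nM.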

Compound 4, half-maximal effective concentration: 165 nM
Beside the measured number, compound 4's estimate is 2.4-fold (0.37 log units) below it; low and high end bracket the measured number.
By their numbers in this assay, from the lowest: compounds 1, 2 and 4 (each within the scatter of the next, the first and the last beyond it). At a limit, above all of these: compound 3.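

Compound 3 is reported in this assay only as a limit, > 1000 nM. On this double-bonded chain carbon, a 3-chlorophenyl group in place of carboxy gives an at least 6.0-fold lower number from compound 3 to compound 4 (0.78 log units; beyond the scatter), so the earlier recovery with 2-fluorophenyl is not unique to that ring, though the choice of ring still registers, with a 2.6-fold higher number from compound 1 to compound 4 (0.41 log units; beyond the scatter). Lengthening from 3-chlorophenyl to 2-(3-chlorophenyl)ethenyl on the aromatic carbon gives a 1.8-fold higher number from compound 2 to compound 4 (0.24 log units; within the scatter), which lies within the scatter.

Still open, from the compounds shown here alone, is how an amine or a plain phenyl group would fare at this place. Also open, going by these compounds, is whether the halogen itself or its place on the ring separates 3-chlorophenyl from 2-fluorophenyl.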